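The source may report more compounds than this note shows. Statements on the series, on what has been measured and on what is new or still open speak of the compounds shown alone.

Of the compounds shown here, three built on a shared core have been measured in a functional assay on MDA-MB-435 cells (Homo sapiens) for inhibition; on this read-out higher numbers stand for weaker inhibition and lower numbers for stronger inhibition. Compound 1 `COc1cc[nH]c1/C=C1\C(=O)Nc2ccc(F)c(C#C[C@@H](N)[C@@H](C)O)c21` gives 300 nM, compound 2 `CN[C@H](C#Cc1c(F)ccc2c1/C(=C/c1[nH]ccc1OC)C(=O)N2)[C@@H](C)O` gives 358 nM, and compound 3 `CCN[C@H](C#Cc1c(F)ccc2c1/C(=C/c1[nH]ccc1OC)C(=O)N2)[C@@H](C)O` gives 1070 nM. Compound 3 therefore has the highest number of the three, which makes it the weakest inhibitor of this small set.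

The next compound is compound 4 `COc1cc[nH]c1/C=C1\C(=O)Nc2ccc(F)c(C#C[C@@H]3C[C@H](O)CN3)c21`. The change from compound 3 is 4-hydroxypyrrolidin-2-yl in place of 1-(ethylamino)-2-hydroxypropyl on a triple-bonded carbon. In words, 4-hydroxypyrrolidin-2-yl stands in place of 1-(ethylamino)-2-hydroxypropyl on a triple-bonded carbon, so the open chain gives way to one five-membered non-aromatic ring.

Among the measured compounds shown here, no measured step makes this exact change, so only indirect guidance exists. Among the three measured compounds, the steps that bear on it concern the group on the amine nitrogen. Putting methyl on that nitrogen gave a 1.2-fold higher number from compound 1 to compound 2 (0.08 log units; within the scatter). Ethyl gave a 3.6-fold higher number from compound 1 to compound 3 (0.55 log units; beyond the scatter), and lengthening methyl to ethyl gave a 3.0-fold higher number from compound 2 to compound 3 (0.48 log units; beyond the scatter). Compound 4 no longer carries the ethyl group, so a modest move back toward compound 1 and compound 2 seems likely in this assay. The expected change is a 2.1-fold lower number from compound 3 to compound 4 (0.33 log units; beyond the scatter). For compound 4 the estimated value is 500 nM, with an expected range from 170 nM to 1400 nM.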

Compound 4, half-maximal inhibitory concentration: 110 nM
Estimate against measurement, compound 4: 4.5-fold (0.66 log units) above; the whole stated range lies above it.
By their numbers in this assay, from the lowest: compound 4; then compounds 1 and 2 (each within the scatter of the next); then compound 3.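

In this assay, among the compounds shown here, replacing the open chain on the triple-bonded carbon with 4-hydroxypyrrolidin-2-yl gives a much larger change than the earlier steps on the amine nitrogen (a 9.7-fold lower number from compound 3 to compound 4 (0.99 log units; beyond the scatter)). For the compounds shown here, the gain is not just the loss of the ethyl group, since the ring also improves on the open chain with a methyl on its nitrogen (a 3.3-fold lower number from compound 2 to compound 4 (0.51 log units; beyond the scatter)) and on the one with no added group there (a 2.7-fold lower number from compound 1 to compound 4 (0.44 log units; beyond the scatter)), which makes compound 4 the strongest inhibitor of the four and shows that this position accepts a ring as well as an open chain. Nothing available here points to the cause of this gain.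

As far as these compounds go, compound 4 brings the ring and its hydroxyl together, so the share of each in the gain stays open, and a plain pyrrolidin-2-yl group on the same triple-bonded carbon would separate them. From the compounds shown here alone, it is also open whether a larger piperidine ring would do as well, and whether an ethyl group on the ring nitrogen would raise the number as it did on the open chain.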